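The compounds below may be only part of what the source reports. "The series", "measured", "known", "first", "only" and "open" are said of these compounds alone.

Two compounds of the series have numbers in an assay on CHO cells for inhibition of metabotropic glutamate receptor 1 (Rattus norvegicus); a lower number here means a stronger inhibitor, a higher number a weaker inhibitor. Compound 1 `CCCOC(=O)c1[nH]c(COC(C)=O)c(C(=O)OC(C)(C)C)c1C` gives 2700 nM in this assay, the lower of the two. Compound 2 `C=CCOC(=O)Cn1c(C)c(C(=O)OC(C)(C)C)c(C)c1C(=O)OCCC` gives 12600 nM in this assay, a number beyond the scatter above that of compound 1. Compound 3 `CCCOC(=O)c1[nH]cc(C(=O)OC(C)(C)C)c1C` has not been measured in this assay; it differs from compound 1 by hydrogen in place of acetoxymethyl on an aromatic carbon. Going by the values given here, no measured pair shows this change, so its size is an expectation only. The expected step in this assay is a 2.2-fold higher number from compound 1 to compound 3 (0.35 log units; beyond the scatter), a modest move toward a higher number. The estimate for compound 3 in this assay is 6000 nM, within 2000 nM to 20000 nM.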

Compound 3, half-maximal inhibitory concentration: 75 nM
Beside the measured number, compound 3's estimate is 80-fold (1.90 log units) above it; measured number below the stated range.
By their numbers in this assay, from the lowest: compound 3; then compound 1; then compound 2.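

In this assay, replacing acetoxymethyl with hydrogen on the aromatic carbon next to the ring nitrogen gives a 36-fold lower number from compound 1 to compound 3 (1.56 log units; beyond the scatter), a large step from a single change. This position therefore strongly affects the number in this pair, and the acetoxymethyl group is not needed for a low number on this core. Nothing available explains the size of this step. As far as these compounds go, it remains open whether hydroxymethyl or an amine on this carbon would stay close to hydrogen or to acetoxymethyl. From the compounds shown here alone, whether the step carries over to other esters on the core also remains open.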